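Cinnamoyl for Trifluoromethylbenzoyl on a Triazole Analogue

A few compounds are considered here, and "the series" means these few. Any claim that something is new, unique, unknown or untested is made for them only; others in the source may bear on it.

Of the compounds shown here, three sharing a core have been measured in a functional assay on NCI-H1975 cells (Homo sapiens) for inhibition, read by sulforhodamine B assay, tested at 10 uM; on this read-out lower numbers stand for less inhibition and higher numbers for more inhibition at the one concentration tested (going by the name of the read-out). Compound 1 `CN1CCN(c2ccc(C3=NN(C(=O)c4ccc(C(F)(F)F)cc4)C(c4ccc(N(C)C)cc4)C3)cc2)CC1` gives 93.2%. Compound 2 `CN1CCN(c2ccc(C3=NN(C(=O)/C=C/c4ccccc4)C(c4ccc(N(C)C)cc4)C3)cc2)CC1` gives 81%. Compound 3 `CN(C)c1ccc(C2CC(c3ccc(-n4cncn4)cc3)=NN2C(=O)c2ccc(C(F)(F)F)cc2)cc1` gives 11.5%, the lowest of the three. Compound 2 differs from compound 1 by 2-phenylethenyl in place of 4-(trifluoromethyl)phenyl on a carbonyl carbon, a change that produced a number 12.2 percentage points lower from compound 1 to compound 2 (beyond the scatter). Compound 3 differs from compound 1 in its core by 1H-1,2,4-triazol-1-yl in place of 4-methylpiperazin-1-yl on an aromatic carbon, and this change produced a number 81.7 percentage points lower from compound 1 to compound 3 (beyond the scatter).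

Compound 4 `CN(C)c1ccc(C2CC(c3ccc(-n4cncn4)cc3)=NN2C(=O)/C=C/c2ccccc2)cc1` has not yet been measured. It differs from compound 3 by 2-phenylethenyl in place of 4-(trifluoromethyl)phenyl on a carbonyl carbon, the same change as from compound 1 to compound 2, made at the same place. Since the earlier pair showed a number 12.2 percentage points lower from compound 1 to compound 2 (beyond the scatter), a modest fall would be the first guess here as well. The expected step in this assay is a number 5.5 percentage points lower from compound 3 to compound 4 (within the scatter). It is kept small because compound 3 gives only 11.5%, leaving little room to fall further. Compound 4 is therefore expected to give 6%, most likely between 0% and 20%.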

Compound 4, a percentage reported as inhibition, at one concentration (the size of the read-out at that concentration, not a potency): -2.3%
Compound 4: the middle estimate sits 8.3 percentage points above what was measured; the whole stated range lies above it.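

Putting 2-phenylethenyl in place of 4-(trifluoromethyl)phenyl on the carbonyl carbon gave a number 13.8 percentage points lower from compound 3 to compound 4 (beyond the scatter), and this step matches the one seen on the core of compound 1: the same change on two cores in this assay, a number 12.2 percentage points lower (beyond the scatter) from compound 1 to compound 2 and a number 13.8 percentage points lower (beyond the scatter) from compound 3 to compound 4, 1.6 percentage points apart, within the scatter of two such steps. The other change carried over in the same way, with 1H-1,2,4-triazol-1-yl in place of 4-methylpiperazin-1-yl giving a number 83.3 percentage points lower from compound 2 to compound 4 (beyond the scatter), so in these four compounds each change had much the same size whichever form the other place took: the same change on two cores in this assay, a number 81.7 percentage points lower (beyond the scatter) from compound 1 to compound 3 and a number 83.3 percentage points lower (beyond the scatter) from compound 2 to compound 4, 1.6 percentage points apart, within the scatter of two such steps. This rests on only two forms at each place, tested at one concentration in this assay, so it does not show that the steps would hold for other groups or cores, and it does not explain why either change lowers the number.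

Still open, on these data alone, is whether a morpholine or a simple primary amine on the aromatic carbon would keep the high numbers of compound 1 and compound 2. Also open, as far as these compounds go, is how a saturated 2-phenylethyl chain on the carbonyl carbon would compare with 2-phenylethenyl.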